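Hydroxymethyl extension and rat clearance in two cores

This account rests on a few compounds, and the source may have more. Where it says the series, first, only, none or still open, it means among the compounds named here.

Compound 1 `COc1ccccc1C1C(C(=O)C(C)(C)C)=C(O)C(=O)N1c1ccc(-c2ccon2)cc1` and compound 2 `CC(C)(C)C(=O)C1=C(O)C(=O)N(c2ccc(-c3ccon3)cc2)C1c1ccccc1OCCO` share one core; compound 3 `COc1ccccc1C1C(C(=O)C(C)C)=C(O)C(=O)N1c1ccc(-c2ccsc2)cc1` and compound 4 `CC(C)C(=O)C1=C(O)C(=O)N(c2ccc(-c3ccsc3)cc2)C1c1ccccc1OCCO` share another, and the difference between the two cores is not broken down here. In an ADME assay on the whole organism (Rattus norvegicus) for pharmacokinetics (a higher number here means faster removal of the compound, a lower number slower removal), compound 1 gives 1.3 mL/min/kg, compound 2 gives 2.9 mL/min/kg, and compound 3 gives 0.3 mL/min/kg, the lowest of the three measured numbers. Going by the values given here, the one change measured within a core is hydroxymethyl in place of hydrogen on a saturated chain carbon bound to an oxygen on an aromatic ring, and it made a 2.2-fold higher number from compound 1 to compound 2 (0.35 log units; beyond the scatter). The same change, (hydroxymethyl in place of hydrogen on a saturated chain carbon bound to an oxygen on an aromatic ring), takes compound 3 to compound 4; the place is described in the same words in both pairs, so this is the same change made in the second core. Going by these compounds, it has been measured only once, so its size on the second core is unknown, and the expectation here is that it carries over without large distortion. Among the compounds with values here, the step expected for compound 4 in this assay is a 2.2-fold higher number from compound 3 to compound 4 (0.34 log units; beyond the scatter), placed beside the earlier measured step because a 2.2-fold higher number from compound 1 to compound 2 (0.35 log units; beyond the scatter) is the only record of this change. Compound 4 is expected to give 0.65 mL/min/kg, between 0.25 mL/min/kg and 1.8 mL/min/kg, the width allowing for the different core and the lower starting number of compound 3.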

Compound 4, clearance: 3.9 mL/min/kg
Compound 4: the middle estimate sits 6.0-fold (0.78 log units) below what was measured, and the stated range ends below it.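

In this assay, the hydroxymethyl change gives a 13-fold higher number from compound 3 to compound 4 (1.11 log units; beyond the scatter), and this step does not match the one measured on the other core: the same change on two cores in this assay, a 2.2-fold higher number (0.35 log units; beyond the scatter) from compound 1 to compound 2 and a 13-fold higher number (1.11 log units; beyond the scatter) from compound 3 to compound 4, 5.8-fold (0.77 log units) apart, beyond the scatter of two such steps
The number rises in both pairs, but the size of the step does not carry from one core to the other, so a step read on one of these cores is a poor guide to its size on the other. These two pairs do not show which of the differences between the cores sets the gap, nor whether the low starting value of compound 3, 0.3 mL/min/kg, plays a part, and two pairs cannot establish a rule for any further core.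

Still open, going by these compounds, is which of the parts that differ between the two cores goes with the larger step, a question that hybrids of the two cores, each carrying 2-methoxyphenyl and 2-(2-hydroxyethoxy)phenyl, could address. Also open, on these data alone, is whether the step depends on the terminal hydroxyl itself or on the chain, which could be tested on both cores with a longer chain such as 3-hydroxypropoxy, or with an amine or a carboxylic acid at the end of the chain.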